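The source may hold more compounds than are shown below. What is called first, only, known or untested is meant among the compounds shown, and "the series" means these compounds.

Measured in a functional assay on NCI-H1975 cells (Homo sapiens) for antiproliferative activity, read by MTT assay, with a stated time of 72 h; a lower number here means a stronger inhibitor, a higher number a weaker inhibitor:
compound 1, `C#Cc1cccc(Nc2ncnc3cc(OC)c(OCCCCC(=O)Nc4ccc(S(N)(=O)=O)cc4)cc23)c1`, gives 18800 nM
compound 2, `COc1cc2ncnc(Nc3cccc(Cl)c3F)c2cc1OCCCCC(=O)Nc1ccc(S(N)(=O)=O)cc1`, gives 6930 nM
compound 3, `COc1cc2ncnc(Nc3ccc(OC(F)(F)F)cc3)c2cc1OCCCCC(=O)Nc1ccc(S(N)(=O)=O)cc1`, gives 8770 nM

Compound 3 holds the second highest of the three numbers. Its nearest neighbour is compound 2, with a step within the scatter (a 1.3-fold higher number from compound 2 to compound 3 (0.10 log units; within the scatter)); its furthest is compound 1 (a 2.1-fold lower number from compound 1 to compound 3 (0.33 log units; beyond the scatter)). Every measured step in this set changes only the group on the nitrogen on the aromatic ring of the shared core, and no other part of the molecule has been varied.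

Compound 4, `COc1cc2ncnc(Nc3cc(F)c(F)c(F)c3)c2cc1OCCCCC(=O)Nc1ccc(S(N)(=O)=O)cc1`, differs from compound 3 in that same place: 3,4,5-trifluorophenyl in place of 4-(trifluoromethoxy)phenyl on a nitrogen on an aromatic ring. For the measured compounds named here, the steps that bear on this change are a 2.7-fold lower number from compound 1 to compound 2 (0.43 log units; beyond the scatter), a 2.1-fold lower number from compound 1 to compound 3 (0.33 log units; beyond the scatter) and a 1.3-fold higher number from compound 2 to compound 3 (0.10 log units; within the scatter). The whole spread of aryl replacements so far is modest, and the two replacements carrying halogens, in compounds 2 and 3, sit within the scatter of each other. The step expected for compound 4 is therefore a 1.2-fold lower number from compound 3 to compound 4 (0.07 log units; within the scatter), most likely within the scatter and without a firm direction. Compound 4 is estimated at 7500 nM in this assay, with a range of 3000 nM to 19000 nM.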

Compound 4, half-maximal inhibitory concentration: 20000 nM
Beside the measured number, compound 4's estimate is 2.7-fold (0.43 log units) below it, outside the stated range (above it).
By their numbers in this assay, from the lowest: compounds 2 and 3 (each within the scatter of the next); then compounds 1 and 4 (each within the scatter of the next).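

In this assay, the halogen-bearing aryl groups no longer fall together: the change to 3,4,5-trifluorophenyl gives a 2.3-fold higher number from compound 3 to compound 4 (0.36 log units; beyond the scatter), and the comparison with the 3-chloro-2-fluorophenyl group gives a 2.9-fold higher number from compound 2 to compound 4 (0.46 log units; beyond the scatter), both beyond the scatter. Against the 3-ethynylphenyl group, the same aryl group gives a 1.1-fold higher number from compound 1 to compound 4 (0.03 log units; within the scatter), so compound 4 sits with compound 1 rather than with compounds 2 and 3, and the presence of halogen on the aryl group does not by itself place a compound in the lower pair. Nothing available accounts for this separation.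

From the compounds shown here alone, it remains open whether an aryl group bearing an amine or a carboxylic acid would move the number at this nitrogen. Also open, going by these compounds, is how a shorter or longer chain to the sulfonamide-bearing amide would read beside these aryl changes.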